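A pyridine for a thiophene on the shared core

A few compounds are considered here, and "the series" means these few. Any claim that something is new, unique, unknown or untested is made for them only; others in the source may bear on it.

Compound 1 `O=C(/C=C/c1cn(-c2ccccc2)nc1-c1ccsc1)c1ccccc1` gives 4700 nM in a functional assay on Huh-7 cells (Homo sapiens) for inhibition, read by sulforhodamine B assay, with a stated time of 72 h (on this read-out lower numbers stand for stronger inhibition and higher numbers for weaker inhibition), and stands highest of the three numbers recorded. Compound 2 `COc1ccc(C(=O)/C=C/c2cn(-c3ccccc3)nc2-c2ccsc2)c(OC)c1OC` gives 4200 nM, which lies within the scatter of compound 1. Compound 3 `COc1ccc(OC)c(C(=O)/C=C/c2cn(-c3ccccc3)nc2-c2ccsc2)c1` gives 2100 nM; the step of a 2.2-fold lower number from compound 1 to compound 3 (0.35 log units; beyond the scatter) comes from 2,5-dimethoxyphenyl in place of phenyl on a carbonyl carbon. Compound 4 `O=C(/C=C/c1cn(-c2ccccc2)nc1-c1cccnc1)c1ccccc1` differs from compound 1 by pyridin-3-yl in place of thiophen-3-yl on an aromatic carbon. Within the data shown here, none of the measured steps touches this part of the molecule; each of them alters only the group on the carbonyl carbon. Nothing measured therefore bears on the change, and no step beyond the scatter is expected in this assay. The expected step is no change at the digits printed from compound 1 to compound 4 (within the scatter). Compound 4 is estimated to give 4700 nM, with a range from 1800 nM to 12000 nM.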

Compound 4, half-maximal inhibitory concentration: 2300 nM
For compound 4 the middle estimate is 2.0-fold (0.31 log units) above the measured one; the measured number falls inside the stated range.
By their numbers in this assay, from the lowest: compounds 3, 4, 2 and 1 (each within the scatter of the next, the first and the last beyond it).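

The earlier steps shown here altered only the group on the carbonyl carbon, whereas this one shows that the number in this assay also responds at the aromatic carbon of the shared core. Pyridin-3-yl in place of thiophen-3-yl gives a 2.0-fold lower number from compound 1 to compound 4 (0.31 log units; beyond the scatter) and so is a modest step. Nothing measured explains this step.

The change swaps both ring size and hetero atom, so the compounds shown do not separate the two; furan-3-yl or pyridin-4-yl here would bear on that. As far as these compounds go, whether the step adds to that from 2,5-dimethoxyphenyl remains open.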